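A few compounds are considered here, and "the series" means these few. Any claim that something is new, unique, unknown or untested is made for them only; others in the source may bear on it.

Measured compounds:
compound 1 `COc1ccc(/C=C/C2CC(=O)C=CO2)cc1`: 149 uM
compound 2 `COc1ccc(/C=C/C2CC(=O)C=CO2)cc1OC`: 89.6 uM
compound 3 `COc1ccc(/C=C/C2CC=CC(=O)N2)cc1`: > 1090 uM (a limit)

In a functional assay on NCI-H460 cells (Homo sapiens) for inhibition, read by sulforhodamine B assay, with a stated time of 48 h (on this read-out higher numbers stand for weaker inhibition of growth and lower numbers for stronger inhibition of growth), compound 1 gives 149 uM and compound 2 gives 89.6 uM. The change between them, (methoxy in place of hydrogen on an aromatic carbon), gave a 1.7-fold lower number from compound 1 to compound 2 (0.22 log units; within the scatter). For compound 3 this assay reports only a limit, > 1090 uM; that is the limit of > 1090 uM in this assay, at which 1 of the 3 values shown sits. How the core of compound 3 differs from that of compound 1 is not broken down here. Compound 4 `COc1ccc(/C=C/C2CC=CC(=O)N2)cc1OC` has not yet been measured; it differs from compound 3 by methoxy in place of hydrogen on an aromatic carbon, the same kind of change as that from compound 1 to compound 2. Given that the earlier step, a 1.7-fold lower number from compound 1 to compound 2 (0.22 log units; within the scatter), lay within the scatter, compound 4 is expected to stay near the limit, with a step estimated at a step that the limit leaves unreadable from compound 3 to compound 4. Compound 4 is estimated to give 1200 uM, between 500 uM and 3000 uM.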

Compound 4, concentration for growth inhibition (reported as GI): > 964 uM
Compound 4 ended at the assay's limit (the forecaster's own chance of this, stated with the estimate: 75%); the middle value is on the limit's open side.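

In this assay, compound 3 and compound 4 each give only a limit, so the step between them cannot be read. The compounds shown leave open whether methoxy in place of hydrogen on an aromatic carbon changes growth inhibition on the core of compound 3.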